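This account rests on a few compounds, and the source may have more. Where it says the series, first, only, none or still open, it means among the compounds named here.

In an assay on isolated protein for inhibition of DNA topoisomerase 1 (Homo sapiens), with a stated time of 30 min, tested at 100 uM (a lower number here means a weaker effect, a higher number a stronger effect of the compound at the concentration tested), three compounds have been measured. Compound 1 `Oc1cccc(-c2cc(-c3cccnc3)nc(-c3cccc(Cl)c3)c2)c1` gives 27.6%. Compound 2 `Oc1cccc(-c2cc(-c3ccncc3)nc(-c3cccc(Cl)c3)c2)c1` differs from compound 1 in one place: pyridin-4-yl in place of pyridin-3-yl on an aromatic carbon. In this assay compound 2 gives 0%, and the step is a number 27.6 percentage points lower from compound 1 to compound 2 (beyond the scatter). Compound 3 `Oc1ccc(-c2cc(-c3cccnc3)nc(-c3cccc(Cl)c3)c2)cc1` differs from compound 1 in another place: 4-hydroxyphenyl in place of 3-hydroxyphenyl on an aromatic carbon. In this assay compound 3 gives 55.2%, the step being a number 27.6 percentage points higher from compound 1 to compound 3 (beyond the scatter), so compound 3 stands highest of the three measured compounds.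

Compound 4 `Oc1ccc(-c2cc(-c3ccncc3)nc(-c3cccc(Cl)c3)c2)cc1` has not yet been measured. It differs from compound 3 as follows: pyridin-4-yl in place of pyridin-3-yl on an aromatic carbon. This is the same kind of change as the one from compound 1 to compound 2, which occurs twice among these four compounds and has been measured once, giving a number 27.6 percentage points lower from compound 1 to compound 2 (beyond the scatter). It is not the same change, since the surroundings differ: in compound 1 the place is meta to a 3-hydroxyphenyl group, in compound 3 it is meta to a 4-hydroxyphenyl group, which is the difference between the two cores described with compound 3. One earlier example is a thin basis, and compound 2 reached the bottom of the scale, so the full size of that step is not known.

Among the compounds with values here, the expected step is a number 30.2 percentage points lower from compound 3 to compound 4 (beyond the scatter) in this assay, resting on the single earlier example because it gave a number 27.6 percentage points lower from compound 1 to compound 2 (beyond the scatter). Compound 4 is therefore estimated at 25% in this assay, with a likely range from 0% to 48%.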

Compound 4, a percentage reported as inhibition, at one concentration (the size of the read-out at that concentration, not a potency): 29.2%
Estimate against measurement, compound 4: 4.2 percentage points below, and the stated range covers the measured number.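

Replacing pyridin-3-yl with pyridin-4-yl on the core of compound 3 gives a number 26 percentage points lower from compound 3 to compound 4 (beyond the scatter) in this assay, and this change carries over from one core to the other with much the same size: the same change on two cores in this assay, a number 27.6 percentage points lower (beyond the scatter) from compound 1 to compound 2 and a number 26 percentage points lower (beyond the scatter) from compound 3 to compound 4, 1.6 percentage points apart, within the scatter of two such steps

The other change, 4-hydroxyphenyl in place of 3-hydroxyphenyl, gives a number 29.2 percentage points higher from compound 2 to compound 4 (beyond the scatter) and also carries over: the same change on two cores in this assay, a number 27.6 percentage points higher (beyond the scatter) from compound 1 to compound 3 and a number 29.2 percentage points higher (beyond the scatter) from compound 2 to compound 4, 1.6 percentage points apart, within the scatter of two such steps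

Within these four compounds, then, each change shifts the read-out by a similar amount whichever form the other group takes, but this rests on just two pairs of steps at one concentration, and compound 2 gives 0%, the bottom of the scale, so the steps that involve it may understate the real difference and nothing here shows that the pattern extends to other cores.

From the compounds shown here alone, the 3-chlorophenyl group is the same in all four compounds, so its contribution remains open, as does whether a fluorine or a methyl group in place of its chlorine would leave these steps intact. It is also open whether the hydroxyl group itself matters, which a 4-methoxyphenyl group in its place could test, and how a pyridin-2-yl group would compare with the two pyridines shown.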